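The source may report more compounds than this note shows. Statements on the series, on what has been measured and on what is new or still open speak of the compounds shown alone.

Compound 1 `CC1=CC[C@@H]([C@@](C)(O)CCCC(C)(C)NC(=S)N/N=C\c2ccc(N(C)C)cc2)CC1`. In a functional assay on PCO3 cells (Homo sapiens) for cytotoxicity, read by sulforhodamine B assay (on this read-out lower numbers stand for stronger inhibition of growth and higher numbers for weaker inhibition of growth), compound 1 does not reach a number but only a limit, > 100000 nM.
Compound 2 `CC1=CC[C@@H]([C@@](C)(O)CCCC(C)(C)NC(=S)N/N=C\c2cccc([N+](=O)[O-])c2)CC1`. In this assay compound 2 gives 20700 nM.
Compound 3 `CC1=CC[C@@H]([C@@](C)(O)CCCC(C)(C)NC(=S)N/N=C\c2ccc([N+](=O)[O-])cc2)CC1`, not yet measured.

Within the data shown here, compound 2 therefore holds the only actual number seen so far. The other result is a limit, namely (the limit of > 100000 nM in this assay, at which 1 of the 2 values shown sits). Among the measured compounds shown here, the single measured step, an at least 4.8-fold lower number from compound 1 to compound 2 (0.68 log units; beyond the scatter), swaps one whole substituent on the phenyl ring for a different one, and counts as at least modest. Compound 3 keeps the nitro group of compound 2 and only moves it: 4-nitrophenyl in place of 3-nitrophenyl on a carbon with a double bond to nitrogen. For the measured compounds named here, no measured step compares two placements of the same nitro group, so the one step seen is only a loose guide. The expectation in this assay is a change no larger than the usual scatter, a 1.0-fold lower number from compound 2 to compound 3 (0.01 log units; within the scatter), with real uncertainty either way. Compound 3 is estimated at 20000 nM, within 6000 nM to 70000 nM.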

Compound 3, concentration for total growth inhibition: > 100000 nM
Compound 3 gave a limit, no number; the forecaster's own chance of this, stated with the estimate: 15%; middle value at least 5.0-fold (0.69 log units) from the limit.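

Moving the nitro group matters in this assay: with the same atoms joined differently, 4-nitrophenyl in place of 3-nitrophenyl gives an at least 4.8-fold higher number from compound 2 to compound 3 (0.68 log units; beyond the scatter). So at this place on the carbon with a double bond to nitrogen, the read-out depends on where the nitro group sits on the phenyl ring, not only on which substituent the ring carries. Compound 1 and compound 3 both end in a limit, so the step between them cannot be read: the limit of > 100000 nM in this assay, at which 2 of the 3 values shown sit.

From the compounds shown here alone, compound 2 alone gives an actual number, so how far compound 3 truly lies from it remains unknown. Going by these compounds, it also remains open whether the number of compound 2 is specific to 3-nitrophenyl, or whether a nitrile or a carboxylic acid on the phenyl ring in place of the nitro group would give a similar result.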